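The compounds below may be only part of what the source reports. "The series", "measured", "known", "first", "only" and "open" are said of these compounds alone.

Two compounds of the series have numbers in an assay on a protein complex for inhibition of CDK8/Cyclin C (Homo sapiens), with a stated time of 1 h; a lower number here means a stronger inhibitor, a higher number a weaker inhibitor. Compound 1 `CCOC(=O)/C=C/c1ccncc1-c1ccc2[nH]ccc2c1` gives 107 nM. Compound 2 `CNC(=O)/C=C/c1ccncc1-c1ccc2c(ccn2C)c1` gives 77.6 nM, the lowest of the two numbers, with compound 1 nearest to it and within the scatter. Compound 3 `CNC(=O)/C=C/c1ccncc1-c1ccc2[nH]ccc2c1` differs from compound 2 by hydrogen in place of methyl on an aromatic nitrogen. Within the data shown here, no measured pair shows this change on its own, so its size in this assay is open; nothing beyond the scatter is expected in either direction. Compound 3 is estimated at 85 nM, between 35 nM and 200 nM. The expected step is a 1.1-fold higher number from compound 2 to compound 3 (0.04 log units; within the scatter).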

Compound 3, half-maximal inhibitory concentration: 51.9 nM
The estimate for compound 3 lay 1.6-fold (0.21 log units) above the measured number; the range from low to high includes it.
By their numbers in this assay, from the lowest: compounds 3, 2 and 1 (each within the scatter of the next, the first and the last beyond it).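

In this assay, hydrogen in place of methyl on the aromatic nitrogen gives a 1.5-fold lower number from compound 2 to compound 3 (0.17 log units; within the scatter) and so leaves the number within the scatter for this pair. Methylamino in place of ethoxy on the carbonyl carbon gives a 2.1-fold lower number from compound 1 to compound 3 (0.31 log units; beyond the scatter) as a modest step, the only one here beyond the scatter. Nothing available explains either step. On these data alone, whether an ethyl group on the aromatic nitrogen, or a dimethylamino or hydroxyl group on the carbonyl carbon, would hold these numbers stays open. The methylamino and ethoxy comparison is also read only with hydrogen on the aromatic nitrogen.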